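The source may report more compounds than this note shows. Statements on the series, on what has been measured and on what is new or still open speak of the compounds shown alone.

Compound 3 `c1cnc(-c2ccccc2OCC2=NCCN2)nc1` stands only at a limit in a functional assay for activation of Alpha-1D adrenergic receptor (Homo sapiens), read by calcium flux; a lower number here means that less compound is needed, a higher number that more compound is needed for the effect: compound 3 gives < 100000 nM, a limit rather than a number. Compound 2 `c1ccc(-c2ccncc2)c(OCC2=NCCN2)c1` likewise gives < 100000 nM in this assay, again a limit. The step that the two limits leave unreadable from compound 2 to compound 3 thus cannot be read, as both values rest on (the limit of < 100000 nM in this assay, at which 2 of the 3 values shown sit). Compound 1 `CCN(CC)C(=O)c1ccccc1OCC1=NCCN1` gives < 5020 nM in this assay, also a limit, the one described by the limit of < 5020 nM in this assay, at which 1 of the 3 values shown sits. Compound 4 `c1ccc(-c2ccns2)c(OCC2=NCCN2)c1` differs from compound 3 by 1,2-thiazol-5-yl in place of pyrimidin-2-yl on an aromatic carbon. Within the data shown here, no measured step bears on this exchange, so the step that the limit leaves unreadable from compound 3 to compound 4 is expected without a measured anchor and is held near zero. Compound 4 is estimated at 20000 nM in this assay, with a range from 2000 nM to 100000 nM.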

Compound 4, half-maximal effective concentration: 25.1 nM
The estimate for compound 4 lay 800-fold (2.90 log units) above the measured number; measured number outside the range, below it.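

The steps from compound 2 and from compound 3 to compound 4 cannot be read: both those compounds stand only at limits in this assay. The compounds shown leave open how large the gain from 1,2-thiazol-5-yl actually is.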